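This account rests on a few compounds, and the source may have more. Where it says the series, first, only, none or still open, it means among the compounds named here.

Working notes on the series. Compound 1, `Nc1nc(N)c2c(-c3ccsc3)cn([C@@H]3O[C@H](CO)[C@@H](O)[C@H]3O)c2n1`, is the reference point. In a functional assay on HCT-116 cells (Homo sapiens), read by MTT assay, with a stated time of 72 h (on this read-out lower numbers stand for stronger inhibition and higher numbers for weaker inhibition), compound 1 gives > 20000 nM, which is a limit of the assay and not a number. Compound 2, `Cc1nc(N)c2c(-c3ccsc3)cn([C@@H]3O[C@H](CO)[C@@H](O)[C@H]3O)c2n1`, gives > 20000 nM in this assay, again a limit rather than a number. Compound 3, `Nc1nc2c(c(-c3ccsc3)cn2[C@@H]2O[C@H](CO)[C@@H](O)[C@H]2O)c(=O)[nH]1`, gives > 20000 nM in this assay, also a limit. Among the measured compounds shown here, the only one-place step measured, a step that the two limits leave unreadable from compound 1 to compound 2, is methyl in place of amino on an aromatic carbon, and its size cannot be read. For the measured compounds named here, all the series shows so far is the limit of > 20000 nM in this assay, at which 3 of the 3 values shown sit; no step of readable size exists anywhere in it.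

Compound 4, `Nc1nc(N)c2c(-c3ccco3)cn([C@@H]3O[C@H](CO)[C@@H](O)[C@H]3O)c2n1`, has not been measured. It differs from compound 1 by furan-2-yl in place of thiophen-3-yl on an aromatic carbon. Going by the values given here, no measured step bears on a swap of one five-membered aromatic ring for another, and the one step that exists is unreadable, so no readable step in this assay is expected from compound 1 to compound 4, and the estimated step that the limit leaves unreadable from compound 1 to compound 4 simply keeps compound 4 at the limit. For compound 4 the expected value in this assay is 40000 nM, with a range from 15000 nM to 150000 nM.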

Compound 4, half-maximal inhibitory concentration: > 20000 nM
Compound 4 was reported as a limit; the forecaster's own chance of this, stated with the estimate: 90%; the middle value lies beyond the limit too.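

Compound 1 and compound 4 both stand at a limit of this assay, not at numbers, so the step between them cannot be read. The compounds shown leave open what any change to the shared core does to the read-out, with every value resting at one point: the limit of > 20000 nM in this assay, at which 4 of the 4 values shown sit.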